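A few compounds are considered here, and "the series" means these few. Any claim that something is new, unique, unknown or untested is made for them only; others in the source may bear on it.

In a functional assay, with a stated time of 20 min, tested at 2.5 mg/mL (on this read-out higher numbers stand for a stronger effect at the one concentration tested and lower numbers for a weaker effect), the three measured compounds gave these numbers:

Compound 1 `CC(C)[C@@H]1CC[C@@H](C)C[C@@]12N(C)C(=O)[C@@H]1[C@H]3C(=O)NC(=O)[C@H]3ON12`: 67.2%
Compound 2 `CC(C)[C@@H]1CC[C@@H](C)C[C@@]12N(C)C(=O)[C@@H]1[C@H]3C(=O)N(C)C(=O)[C@H]3ON12`: 55.8%
Compound 3 `COc1ccc(N2C(=O)[C@H]3[C@H](ON4[C@@H]3C(=O)N(C)[C@@]43C[C@H](C)CC[C@H]3C(C)C)C2=O)cc1`: 65.3%

Compound 2 stands lowest of the three: its gap to compound 3 is within the scatter, while a number 11.4 percentage points lower from compound 1 to compound 2 (beyond the scatter) lies beyond it. Compound 4 `Cc1ccc(N2C(=O)[C@H]3[C@H](ON4[C@@H]3C(=O)N(C)[C@@]43C[C@H](C)CC[C@H]3C(C)C)C2=O)c(C)c1` differs from compound 2 in one place: 2,4-dimethylphenyl in place of methyl on an amide-type nitrogen in a ring. Among the compounds with values here, two measured steps bear on this change. a number 9.5 percentage points higher from compound 2 to compound 3 (within the scatter) placed a 4-methoxyphenyl where the methyl had been, and a number 1.9 percentage points lower from compound 1 to compound 3 (within the scatter) placed the same group in place of hydrogen; both stayed within the scatter. A 2,4-dimethylphenyl on that nitrogen is therefore expected to bring only a small rise, possibly none beyond the scatter. For compound 4 the expected value is 62%, with a range from 48% to 76%, which amounts to an estimated a number 6.2 percentage points higher from compound 2 to compound 4 (within the scatter).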

Compound 4, a percentage reported as activity, at one concentration (the size of the read-out at that concentration, not a potency): 77.1%
Beside the measured number, compound 4's estimate is 15.1 percentage points below it; measured number outside the range, above it.
By their numbers in this assay, from the lowest: compounds 2, 3, 1 and 4 (each within the scatter of the next, the first and the last beyond it).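

The 2,4-dimethylphenyl group on this amide-type nitrogen gives a gain that 4-methoxyphenyl did not, with a number 21.3 percentage points higher from compound 2 to compound 4 (beyond the scatter) and a number 11.8 percentage points higher from compound 3 to compound 4 (beyond the scatter) showing that a phenyl ring here is not all that counts: what it carries matters too. Against the plain amide hydrogen there is no clear gain, with a number 9.9 percentage points higher from compound 1 to compound 4 (within the scatter) as the step. No measurement available here accounts for these differences. Still open, as far as these compounds go, is which of the two methyl groups matters, and whether an amine or a carboxylic acid on that phenyl ring, or a longer chain on the nitrogen, would change the number.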